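This account rests on a few compounds, and the source may have more. Where it says the series, first, only, none or still open, it means among the compounds named here.

Measured compounds in a functional assay on MCF7 cells (Homo sapiens) for cytotoxicity, read by MTT assay, with a stated time of 72 h; a higher number here means a weaker inhibitor, a lower number a stronger inhibitor:
Compound 1 `Cc1ccc(-c2ccc(C(=O)Nc3ccc(Oc4ccnc5[nH]ccc45)cc3)nc2)cc1` gives > 10000 nM, which is a limit of the assay rather than a number.
Compound 2 `O=C(Nc1ccc(Oc2ccnc3[nH]ccc23)cc1)c1ccc(-c2ccc(F)cc2F)cn1` gives > 10000 nM, also a limit of the assay.
Compound 3 `Cc1ccc(-c2ccc(C(=O)Nc3ccc(Oc4ccnc5[nH]ccc45)c(F)c3)nc2)cc1` gives 8020 nM.

Compound 3 is thus the only one of the three with a number in this assay; the other two sit at the limit of > 10000 nM in this assay, at which 2 of the 3 values shown sit. The step of an at least 1.2-fold lower number from compound 1 to compound 3 (0.09 log units; that floor lies within the scatter) has a floor inside the scatter, so compound 1 and compound 3 cannot be placed in order. Compound 4 `O=C(Nc1ccc(Oc2ccnc3[nH]ccc23)c(F)c1)c1ccc(-c2ccc(Cl)cc2)cn1` has not yet been measured. It differs from compound 3 by chloro in place of methyl on an aromatic carbon. Among the measured compounds shown here, the only measured step that alters the 4-methylphenyl group is a step that the two limits leave unreadable from compound 1 to compound 2, and it cannot be read. No readable measured step therefore speaks to the exchange of methyl for chloro, and the expectation in this assay is a change no larger than the scatter, a 1.0-fold lower number from compound 3 to compound 4 (0.00 log units; within the scatter), as the estimated step. Compound 4 is estimated at 8000 nM, between 3000 nM and 20000 nM, with a fair chance that only a limit is reported.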

Compound 4, half-maximal inhibitory concentration: > 10000 nM
Compound 4 ended at the assay's limit; the forecaster's own chance of this, stated with the estimate: 40%; middle value at least 1.2-fold (0.09 log units) from the limit.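

In this assay, among the compounds shown here, the step of an at least 1.2-fold higher number from compound 3 to compound 4 (0.09 log units; that floor lies within the scatter) gives the first view of a change to the 4-methylphenyl group that starts from a real number, but its floor lies within the scatter, so compound 3 and compound 4 cannot be placed in order. Nothing here shows that chloro in place of methyl, at this carbon para to a large group, lowers the number. The value of compound 4 is a limit, and it joins most of the set there: the limit of > 10000 nM in this assay, at which 3 of the 4 values shown sit.

From the compounds shown here alone, the true size of this step stays open, since one end of it is only a limit. Also open, going by these compounds, is whether a methoxy group, an amine or a carboxylic acid at this place would give a number clearly lower than that of compound 3 (8020 nM).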